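Chloro on a new carbon: what compound 4 may show

The compounds below may be only part of what the source reports. "The series", "measured", "known", "first", "only" and "open" are said of these compounds alone.

- compound 1 `CC(=O)OC[C@H]1O[C@@H](N2C(=O)/C(=C3/C(=O)Nc4ccccc43)c3ccccc32)[C@H](OC(C)=O)[C@@H](OC(C)=O)[C@@H]1OC(C)=O` gives 4530 nM
- compound 2 `CC(=O)OC[C@H]1O[C@@H](N2C(=O)/C(=C3/C(=O)Nc4ccc(I)cc43)c3ccccc32)[C@H](OC(C)=O)[C@@H](OC(C)=O)[C@@H]1OC(C)=O` gives 11300 nM
- compound 3 `CC(=O)OC[C@H]1O[C@@H](N2C(=O)/C(=C3/C(=O)Nc4ccc(Cl)cc43)c3ccccc32)[C@H](OC(C)=O)[C@@H](OC(C)=O)[C@@H]1OC(C)=O` gives 13700 nM

In an ADME assay on L6 cells (Rattus norvegicus) for cytotoxicity, read by resazurin assay, with a stated time of 72 h (on this read-out higher numbers stand for weaker inhibition and lower numbers for stronger inhibition), compound 1 stands lowest of the three measured compounds, at 4530 nM. Compound 4 `CC(=O)OC[C@H]1O[C@@H](N2C(=O)/C(=C3/C(=O)Nc4cc(Cl)ccc43)c3ccccc32)[C@H](OC(C)=O)[C@@H](OC(C)=O)[C@@H]1OC(C)=O` has not yet been measured. Its change from compound 1 is chloro in place of hydrogen on an aromatic carbon, in words chloro in place of hydrogen on an aromatic carbon. For the measured compounds named here, two measured steps bear on this. The closer one is a 3.0-fold higher number from compound 1 to compound 3 (0.48 log units; beyond the scatter), which also brings in chloro, though on a different aromatic carbon. The other is a 2.5-fold higher number from compound 1 to compound 2 (0.40 log units; beyond the scatter), which brings in iodo. Both are modest and point the same way, while a 1.2-fold higher number from compound 2 to compound 3 (0.08 log units; within the scatter) stays within the scatter. Only these two substituted compounds inform the expectation, and neither carries the group where compound 4 does, so a modest rise is expected with a wide margin. The expected step is a 2.2-fold higher number from compound 1 to compound 4 (0.34 log units; beyond the scatter). For compound 4 the estimated value in this assay is 10000 nM, with an expected range of 4500 nM to 22000 nM.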

Compound 4, half-maximal inhibitory concentration: 8270 nM
Estimate against measurement, compound 4: 1.2-fold (0.08 log units) above, and the stated range covers the measured number.
By their numbers in this assay, from the lowest: compounds 1, 4, 2 and 3 (each within the scatter of the next, the first and the last beyond it).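

In this assay, chloro on this carbon, meta to a fused ring and para to a fused ring, gives a 1.8-fold higher number from compound 1 to compound 4 (0.26 log units; within the scatter), so compound 4 cannot be told apart from compound 1 on this read-out. For the compounds shown here, on a different aromatic carbon the same replacement gave a 3.0-fold higher number from compound 1 to compound 3 (0.48 log units; beyond the scatter), so a step beyond the scatter with chloro is not seen on both carbons tried, which the earlier compounds alone could not show. No measurement offered here accounts for this difference between the two carbons.

Going by these compounds, whether iodo on this carbon would give a step like that of chloro remains open. So does the outcome with a group of another kind there, such as an amine or a carboxylic acid.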